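Swapping a Ring-Bearing Side Chain for an Open Amide

A few compounds are considered here, and "the series" means these few. Any claim that something is new, unique, unknown or untested is made for them only; others in the source may bear on it.

Measured compounds:
compound 1 `NC(=O)[C@@H]1CCCN1c1cc(=O)oc2cc(OCc3ccccc3)ccc12` — 16100 nM
compound 2 `NC(=O)Cc1cc(=O)oc2cc(OCc3ccncc3)ccc12` — 2000 nM

In an assay for inhibition of Amine oxidase [flavin-containing] B (Rattus norvegicus) (on this read-out higher numbers stand for weaker inhibition and lower numbers for stronger inhibition), compound 1 gives 16100 nM, the highest of the two numbers; compound 2 gives 2000 nM, a lower number by a gap beyond the scatter. Compound 3 `CN(C)C(=O)Cc1cc(=O)oc2cc(OCc3ccccc3)ccc12` differs from compound 1 by (dimethylcarbamoyl)methyl in place of 2-carbamoylpyrrolidin-1-yl on an aromatic carbon. For the measured compounds named here, no pair of measured compounds differing in one place is available, so the expectation rests on compound 2 alone. The step from compound 1 to compound 3 is expected to be a clear drop in number a 4.6-fold lower number from compound 1 to compound 3 (0.66 log units; beyond the scatter), because compound 2 gives 2000 nM with a side chain that also lacks a ring. Compound 3 is expected to give about 3500 nM, between 700 nM and 17000 nM.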

Compound 3, half-maximal inhibitory concentration: 400 nM
Beside the measured number, compound 3's estimate is 8.8-fold (0.94 log units) above it; the whole stated range lies above it.
By their numbers in this assay, from the lowest: compound 3; then compound 2; then compound 1.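

Replacing 2-carbamoylpyrrolidin-1-yl with (dimethylcarbamoyl)methyl on this aromatic carbon gives a 40-fold lower number from compound 1 to compound 3 (1.60 log units; beyond the scatter) in this assay, so the group at this position has a large effect on the read-out. The change removes the ring, the defined stereocentre and the hydrogen-bond donor all at once, and this single step cannot separate them. No measurement shown explains the step.

Going by these compounds, it remains open how a carboxylic acid or an amine would read in place of the dimethylcarbamoyl group, and whether a longer chain would keep the lower number.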